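A few compounds are considered here, and "the series" means these few. Any claim that something is new, unique, unknown or untested is made for them only; others in the source may bear on it.

Measured so far in a functional assay on A-375 cells (Homo sapiens) for cytotoxicity, read by MTT assay, with a stated time of 72 h, tested at 3 uM; on this read-out higher numbers stand for more inhibition of growth at the one concentration tested and lower numbers for less inhibition of growth:
- compound 1 `N/C(=N\NC(=S)N1CCCCCC1)c1ccccn1`: 78.6%
- compound 2 `Cc1cccc(/C(N)=N/NC(=S)N2CCCCCC2)n1`: 64.5%

Compound 1 stands highest of the two numbers; the nearest, compound 2, lies lower by a number 14.1 percentage points lower from compound 1 to compound 2 (beyond the scatter), a modest step that exceeds the scatter and goes with a methyl in place of hydrogen on an aromatic carbon.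

Compound 3 `N/C(=N\NC(=S)N1CCCCCC1)c1ccc(F)cn1` has not yet been run in this assay. It differs from compound 1 by fluoro in place of hydrogen on an aromatic carbon. For the measured compounds named here, the only measured step, from compound 1 to compound 2, concerns a different substituent entering the same six-membered aromatic ring with one nitrogen, so it bears on the present step only as a rough guide: a single small group placed on that ring cost a modest amount there. Fluorine is a smaller addition than methyl and enters with no hydrogen-bond donors or acceptors, so a smaller loss, or none beyond the scatter, is expected.

Compound 3 is therefore estimated at 71%, within 52% to 88%, which corresponds to an expected step of a number 7.6 percentage points lower from compound 1 to compound 3 (within the scatter).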

Compound 3, percent growth inhibition at one concentration: 66.6%
Estimate against measurement, compound 3: 4.4 percentage points above; the range from low to high includes it.
By their numbers in this assay, from the lowest: compounds 2 and 3 (each within the scatter of the next); then compound 1.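

In this assay, a single fluoro on an aromatic carbon, two atoms from the ring nitrogen and para to a large group, comes with a number 12 percentage points lower from compound 1 to compound 3 (beyond the scatter) and so shows that even this one-atom addition to the ring does not leave the number of compound 1 intact. The methyl change, with a number 14.1 percentage points lower from compound 1 to compound 2 (beyond the scatter) as its step, is therefore no lone case: both ring-substituted compounds lie beyond the scatter from compound 1, which holds the highest number of the three, while compounds 2 and 3 lie within the scatter of each other. Nothing on hand bears on what lies behind the fall seen with the fluoro.

Still open is whether the fall belongs to this carbon or follows any substitution on the ring, since only one group is shown at this place. A chloro, a methoxy or an amine at the same carbon would show whether other groups give a similar step or whether some keep the number of compound 1.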